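The source may hold more compounds than are shown below. What is called first, only, known or untested is meant among the compounds shown, and "the series" means these compounds.

Three compounds share one core and differ only in the aryl group on the sulfonyl sulfur. Compound 1 `CCN(CC)C(=O)CN(c1ccc(C)cc1)S(=O)(=O)c1cccc(C)c1` carries a 3-methylphenyl there. In a functional assay on CHO cells for inhibition of Orexin/Hypocretin receptor type 1 (Homo sapiens), read by FLIPR and calcium flux (a lower number here means a stronger inhibitor, a higher number a weaker inhibitor), compound 1 reaches only the limit of the assay, > 10000 nM. Compound 2 `CCN(CC)C(=O)CN(c1ccc(C)cc1)S(=O)(=O)c1ccccc1C` carries a 2-methylphenyl instead. In this assay compound 2 likewise stops at the limit, > 10000 nM. Compound 3 `CCN(CC)C(=O)CN(c1ccc(C)cc1)S(=O)(=O)c1ccc(Br)cc1` carries a 4-bromophenyl. In this assay compound 3 also sits at the limit, > 10000 nM. Because (the limit of > 10000 nM in this assay, at which 3 of the 3 values shown sit), the steps a step that the two limits leave unreadable from compound 1 to compound 2, a step that the two limits leave unreadable from compound 1 to compound 3 and a step that the two limits leave unreadable from compound 2 to compound 3 cannot be sized. Compound 4 `CCN(CC)C(=O)CN(c1ccc(C)cc1)S(=O)(=O)c1ccccc1F` is the next variant: 2-fluorophenyl in place of 4-bromophenyl on a sulfonyl sulfur. Within the data shown here, none of the measured steps has a readable size, so no direction can be drawn from them, and three aryl variants all failing to register leaves the limit as the most likely outcome again. The expectation is that compound 4 will once more reach only the limit, an expected step that the limit leaves unreadable from compound 3 to compound 4. Compound 4 is therefore estimated at 15000 nM in this assay, within 4000 nM to 60000 nM.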

Compound 4, half-maximal inhibitory concentration: > 10000 nM
Compound 4: only a limit was reported; the forecaster's own chance of this, stated with the estimate: 85%; the middle value does not contradict the limit.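

The steps from compound 4 to compound 1, compound 2 and compound 3 cannot be read, because each value is a limit and not a number: the limit of > 10000 nM in this assay, at which 4 of the 4 values shown sit.

The compounds shown leave open how far these four differ in strength, and whether any aryl group on the sulfonyl sulfur gives a measurable value.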